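Trifluoromethoxy to Methylsulfanyl: An Expected Flat Step

This account rests on a few compounds, and the source may have more. Where it says the series, first, only, none or still open, it means among the compounds named here.

Compound 1 `O=C(CCc1cccc2c1B(O)OC2)Nc1cccc(-c2cccc(Cl)c2)c1`: 350 nM
Compound 2 `O=C(CCc1cccc2c1B(O)OC2)Nc1cccc(-c2cccc(OC(F)(F)F)c2)c1`: 310 nM

Both compounds were tested in a functional assay on HCT-116 cells (Homo sapiens) for antiproliferative activity, read by MTT assay, with a stated time of 72 h; on this read-out lower numbers stand for stronger inhibition and higher numbers for weaker inhibition. There, compound 2 gives 310 nM, which lies within the scatter of the value for compound 1, so neither stands apart from the other. The next compound, compound 3 `CSc1cccc(-c2cccc(NC(=O)CCc3cccc4c3B(O)OC4)c2)c1`, has methylsulfanyl in place of trifluoromethoxy on an aromatic carbon. Going by the values given here, only one measured step bears on this change, and it involves the same aromatic carbon. That step, a 1.1-fold lower number from compound 1 to compound 2 (0.05 log units; within the scatter), replaces chloro with trifluoromethoxy and stays within the scatter. Methylsulfanyl itself has not been tested, so this single step is thin evidence, and no change beyond the scatter is expected in this assay. The expected step is small, a 1.1-fold higher number from compound 2 to compound 3 (0.04 log units; within the scatter). For compound 3 the estimated value is 340 nM, with an expected range of 150 nM to 800 nM.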

Compound 3, half-maximal inhibitory concentration: 110 nM
The estimate for compound 3 lay 3.1-fold (0.49 log units) above the measured number, outside the stated range (below it).
By their numbers in this assay, from the lowest: compound 3; then compounds 2 and 1 (each within the scatter of the next).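

Compounds 1 and 2 could not be told apart, so chloro and trifluoromethoxy alone gave no sign that this aromatic carbon, meta to a large group, matters in this assay. Methylsulfanyl shows that it does, with a 2.8-fold lower number from compound 2 to compound 3 (0.45 log units; beyond the scatter) and a 3.2-fold lower number from compound 1 to compound 3 (0.50 log units; beyond the scatter), so the number at this position can move with the group it carries, and compound 3 stands apart from both others by a modest margin. Nothing measured here explains why methylsulfanyl differs from the other two groups.

The compounds shown leave open whether the sulfur atom is what counts, since a methoxy group on the same carbon would separate sulfur from oxygen directly. They also leave open whether a longer chain such as ethylsulfanyl, or an amine at this place, would keep, extend or lose the lower number of compound 3.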